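This account rests on a few compounds, and the source may have more. Where it says the series, first, only, none or still open, it means among the compounds named here.

In a toxicity assay on MDCK cells (Canis lupus familiaris) for cytotoxicity, read by CCK-8 assay, with a stated time of 48 h (a higher number here means that more compound is tolerated, a lower number that less compound is tolerated), compound 1 `O=C(NNc1c(Br)cccc1Br)c1ccc(OCC(F)(F)F)cc1` gives > 100000 nM, which is a limit of the assay and not a number. Compound 2 `COc1ccccc1C(=O)NNc1c(Br)cccc1Br` gives > 100000 nM, which is also a limit. Compound 3 `O=C(NNc1c(Br)cccc1Br)c1ccc2ncccc2c1` gives > 100000 nM, again a limit. Compound 1 therefore has no exact value and stands level with the other two, as this summary shows: the limit of > 100000 nM in this assay, at which 3 of the 3 values shown sit. Among the measured compounds shown here, no pair of these measured compounds differs in only one place, so the data give no direct guide to the size of a single change.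

Compound 4 `O=C(NNc1c(Br)cccc1Br)c1ccc(-c2ccccc2)cc1` keeps the core of compound 1 and changes one group: phenyl in place of 2,2,2-trifluoroethoxy on an aromatic carbon. In words, phenyl takes the place of 2,2,2-trifluoroethoxy on an aromatic carbon. The expectation is for no step beyond the usual scatter, and any real shift is expected to go toward a lower number, meaning less compound tolerated. The expected step is a number no higher from compound 1 to compound 4 (the limit leaves the size open). For compound 4 the estimated value is 100000 nM, with an expected range from 40000 nM to 200000 nM.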

Compound 4, half-maximal cytotoxic concentration: 84100 nM
Compound 4: middle estimate off by 1.2-fold (0.08 log units), on the high side; low and high end bracket the measured number.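

Phenyl in place of 2,2,2-trifluoroethoxy gives the only exact number among the compounds shown: in this assay compound 4 gives 84100 nM and so falls within the range the assay can measure. The change at this position is an at least 1.1-fold lower number from compound 1 to compound 4 (0.07 log units; that floor lies within the scatter) and therefore cannot be called a real loss of tolerance. As far as these compounds go, its true size stays unknown because compound 1 carries only a limit and not a number, as do most of the values here: the limit of > 100000 nM in this assay, at which 3 of the 4 values shown sit.

The compounds shown leave open whether another group on this aromatic carbon, such as an amine, a carboxylic acid or a longer chain, would move the number clearly beyond the scatter. They also leave open how much a single change elsewhere on the shared core would matter.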